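Piperidine in place of anilines on the shared core

A few compounds are considered here, and "the series" means these few. Any claim that something is new, unique, unknown or untested is made for them only; others in the source may bear on it.

The series shares one core with a variable group on a double-bonded ring carbon. Compound 1 `COc1cccc(NC2=CC(=O)c3c(nc4n3[C@H]3OC[C@@H](O)[C@H]3OC4)C2=O)c1` carries a 3-methoxyphenylamino group, compound 2 `O=C1C(Nc2cccc(Cl)c2)=CC(=O)c2c1nc1n2[C@H]2OC[C@@H](O)[C@H]2OC1` a 3-chlorophenylamino group and compound 3 `COc1ccc(NC2=CC(=O)c3c(nc4n3[C@H]3OC[C@@H](O)[C@H]3OC4)C2=O)cc1` a 4-methoxyphenylamino group. In a functional assay on HeLa cells (Homo sapiens) for inhibition, read by sulforhodamine B assay (on this read-out higher numbers stand for weaker inhibition and lower numbers for stronger inhibition), compound 1 reaches only a limit, > 8000 nM. In this assay compound 2 gives 7970 nM. In this assay compound 3 again stops at a limit, > 8000 nM. The measured steps carry little information: a number no higher from compound 1 to compound 2 (the limit leaves the size open); a step that the two limits leave unreadable from compound 1 to compound 3; a number no lower from compound 2 to compound 3 (the limit leaves the size open). Compound 3 therefore stands where most of the series stands, at the limit of > 8000 nM in this assay, at which 2 of the 3 values shown sit, with compound 2 close by.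

Compound 4 `O=C1C(N2CCCCC2)=CC(=O)c2c1nc1n2[C@H]2OC[C@@H](O)[C@H]2OC1` differs from compound 3 by piperidin-1-yl in place of (4-methoxyphenyl)amino on a double-bonded ring carbon. Within the data shown here, none of the measured steps exchanges the aromatic amine for a saturated one; all three move between substituted phenyl groups and all stay at or near the limit, so none offers a readable size for a change of this kind. The expected step is a step that the limit leaves unreadable from compound 3 to compound 4, none beyond the scatter. Compound 4 is estimated at 9000 nM, between 3000 nM and 30000 nM, and is expected most often to return only a limit.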

Compound 4, half-maximal inhibitory concentration: > 16000 nM
Compound 4 ended at the assay's limit; the forecaster's own chance of this, stated with the estimate: 70%; at least 1.7-fold (0.24 log units) between middle value and limit.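

In this assay, among these compounds, the first exchange of an aromatic amine for a saturated ring at this double-bonded ring carbon gives only one readable step, an at least 2.0-fold higher number from compound 2 to compound 4 (0.30 log units; that floor lies within the scatter) and the steps to compound 4 from the two methoxy anilines cannot be read. With piperidin-1-yl, the group has no aromatic ring and 0 hydrogen-bond donors, yet no stronger inhibition appears, so neither the phenyl ring nor the amine hydrogen of the earlier groups is shown to be something whose removal brings activity in this series. Compound 4 returns only a limit, and it is the only compound shown at this higher limit: the limit of > 16000 nM in this assay, at which 1 of the 4 values shown sits.

The compounds shown cannot tell whether the aromatic or the saturated amine is the better group at this carbon, since the only readable step has a floor within the scatter and its upper size stays open. Morpholin-4-yl, a benzylamino group or an open-chain dialkylamino group at the same carbon would show whether any amine here gives a full value in this assay rather than a limit.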